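Swapping hydroxy for chloro on the aryl ketone

The source may hold more compounds than are shown below. What is called first, only, known or untested is meant among the compounds shown, and "the series" means these compounds.

Measured compounds:
compound 1 `COc1ccc(C(=O)/C=C/c2cc3ccccc3[nH]c2=O)cc1` gives 3600 nM
compound 2 `O=C(/C=C/c1cc2ccccc2[nH]c1=O)c1ccc(O)cc1` gives 3200 nM

Both numbers come from a functional assay on OVCAR-5 cells (Homo sapiens) for cytotoxicity, read by sulforhodamine B assay, with a stated time of 24 h; a lower number here means a stronger inhibitor of growth, a higher number a weaker inhibitor of growth. Compound 2 and compound 1 cannot be told apart on these two measurements, since the step of a 1.1-fold lower number from compound 1 to compound 2 (0.05 log units; within the scatter) is within the scatter; compound 2 is simply one of two equivalent values.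

Compound 3 `O=C(/C=C/c1cc2ccccc2[nH]c1=O)c1ccc(Cl)cc1` has not been measured. It differs from compound 2 in one place: chloro in place of hydroxy on an aromatic carbon. Going by the values given here, the only measured step, a 1.1-fold lower number from compound 1 to compound 2 (0.05 log units; within the scatter), touches the same position of the same ring, yet exchanges one oxygen-bearing group for another, so it says nothing direct about replacing that oxygen with chlorine. Among the compounds with values here, with no step that bears on this change, the expectation can only rest on the value of compound 2, 3200 nM, and must carry a wide range.

Compound 3 is therefore expected to give 3000 nM in this assay, with a range from 800 nM to 12000 nM. This estimate means an expected step of a 1.1-fold lower number from compound 2 to compound 3 (0.03 log units; within the scatter), which is no change beyond the scatter.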

Compound 3, concentration for 50% growth inhibition: 12700 nM
Compound 3: the middle estimate sits 4.2-fold (0.63 log units) below what was measured; measured number outside the range, above it.
By their numbers in this assay, from the lowest: compounds 2 and 1 (each within the scatter of the next); then compound 3.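

The earlier pair, hydroxy and methoxy, could not be told apart, so this position might have seemed indifferent to what sits on it. In this assay, chloro shows otherwise, with a 4.0-fold higher number from compound 2 to compound 3 (0.60 log units; beyond the scatter) and a 3.5-fold higher number from compound 1 to compound 3 (0.55 log units; beyond the scatter), both modest but beyond the scatter, so growth inhibition at this position does depend on the group placed there, and both oxygen-bearing groups do better than chloro. Nothing given here explains why chloro differs from these two groups.

Still open, going by these compounds, is whether this step belongs to chloro itself or would follow from any group without oxygen, which an amine, a methyl or a fluoro at the same position could help separate. Also open, on these data alone, is whether any group here, such as a carboxylic acid, could give a number clearly lower than those of compound 1 and compound 2.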